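Working notes on compounds 1 to 3

The source may report more compounds than this note shows. Statements on the series, on what has been measured and on what is new or still open speak of the compounds shown alone.

Measured in an ADME assay on microsomes from liver (Homo sapiens) for metabolic stability; on this read-out higher numbers stand for fast clearance and lower numbers for slow clearance:
compound 1 `CCC(Oc1ccc(-n2cc(C(F)(F)F)cn2)cc1)c1ccc(C(=O)NCCC(=O)O)cc1` gives < 8 mL/min/kg, which is a limit of the assay and not a number.
compound 2 `O=C(O)CCNC(=O)c1ccc(C(Oc2ccc(-n3cc(C(F)(F)F)cn3)cc2)C2CCC2)cc1` gives 26 mL/min/kg.

Within the data shown here, compound 2 carries the only actual number in this assay; the other value shown is a limit. Among the measured compounds shown here, the step of an at least 3.2-fold higher number from compound 1 to compound 2 (0.51 log units; beyond the scatter) is the one measured change at this position, and since compound 1 sits at the limit of < 8 mL/min/kg in this assay, at which 1 of the 2 values shown sits, only a lower bound on its size is known. Compound 3 `CC(C)CC(Oc1ccc(-n2cc(C(F)(F)F)cn2)cc1)c1ccc(C(=O)NCCC(=O)O)cc1` differs from compound 2 by isobutyl in place of cyclobutyl on a saturated chain carbon bound to an aromatic carbon and an oxygen on an aromatic ring. The entering group is of the same size as the leaving one, so the earlier step bears only loosely here: it shows that enlarging the group from ethyl raised clearance, but says nothing about a ring against an open chain. No change beyond the scatter is expected in this assay, and the estimated step of no change at the digits printed from compound 2 to compound 3 (within the scatter) is accordingly small. Compound 3 is expected at 26 mL/min/kg, within 12 mL/min/kg to 55 mL/min/kg.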

Compound 3, clearance in the Homo sapiens assay: 23 mL/min/kg
Compound 3: the middle estimate sits 1.1-fold (0.05 log units) above what was measured, within the range that was stated.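

In the Homo sapiens assay, isobutyl in place of cyclobutyl gives a 1.1-fold lower number from compound 2 to compound 3 (0.05 log units; within the scatter), so at this position clearance does not tell the ring from the open chain. The higher clearance seen with cyclobutyl over ethyl also appears with isobutyl, at an at least 2.8-fold higher number from compound 1 to compound 3 (0.45 log units; beyond the scatter), but this step is only a lower bound, set by a limit and not a number: the limit of < 8 mL/min/kg in the Homo sapiens assay, at which 1 of the 3 values shown sits. In a physicochemical assay for lipophilicity, using the shake flask method, at pH 7.4 (a higher number here means a more lipophilic compound, a lower number a more polar compound), compound 2 gives 2.6 and compound 3 gives 3.2, a step beyond the scatter, so the two groups are told apart on this read-out though not on clearance.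

From the compounds shown here alone, it remains open whether a cyclopropyl group on this carbon would fall with ethyl or with cyclobutyl on clearance. Also open, going by these compounds, is whether an amine or a hydroxyl on a longer chain here would keep clearance near the limit of compound 1.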